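Methoxy in place of methyl: outlook for compound 4

The source may hold more compounds than are shown below. What is called first, only, known or untested is meant among the compounds shown, and "the series" means these compounds.

Compound 3 `C/C(=N\Nc1nc(-c2ccc(C)cc2)cs1)c1sc(-c2ccccc2)nc1C` reaches only a limit in a toxicity assay on MCF7 cells (Homo sapiens) for cytotoxicity, read by MTT assay; on this read-out higher numbers stand for weaker inhibition of growth and lower numbers for stronger inhibition of growth: compound 3 gives > 100 ug/mL, which is a limit of the assay and not a number. Compound 1 `C/C(=N\Nc1nc(-c2ccccc2)cs1)c1sc(-c2ccccc2)nc1C` likewise gives > 100 ug/mL in this assay, again a limit. Compound 2 `C/C(=N\Nc1nc(-c2ccc(Cl)cc2)cs1)c1sc(-c2ccccc2)nc1C` gives > 100 ug/mL, also a limit. Thus (the limit of > 100 ug/mL in this assay, at which 3 of the 3 values shown sit), and the steps a step that the two limits leave unreadable from compound 1 to compound 2, a step that the two limits leave unreadable from compound 1 to compound 3 and a step that the two limits leave unreadable from compound 2 to compound 3 carry no readable size. Compound 4 `COc1ccc(-c2csc(N/N=C(\C)c3sc(-c4ccccc4)nc3C)n2)cc1` differs from compound 3 by methoxy in place of methyl on an aromatic carbon. Within the data shown here, no measured step bears on this change with a readable size; the related substitutions all sat at the limit. For compound 4 a step that the limit leaves unreadable from compound 3 to compound 4 is therefore expected, most likely ending at another limit. The estimate for compound 4 is 150 ug/mL, within 50 ug/mL to 500 ug/mL.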

Compound 4, concentration for 50% growth inhibition: > 100 ug/mL
Compound 4: no number, only a limit; the forecaster's own chance of this, stated with the estimate: 85%; the middle value does not contradict the limit.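

Among these compounds, no step among compound 1, compound 2, compound 3 and compound 4 can be read in this assay, as each value is a limit and not a number: the limit of > 100 ug/mL in this assay, at which 4 of the 4 values shown sit. The compounds shown leave open whether the hydrogen, chloro, methyl and methoxy members of the series differ from one another at all.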